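Removing One Methoxy Group, Measured Once and Expected Again

The source may hold more compounds than are shown below. What is called first, only, known or untested is meant among the compounds shown, and "the series" means these compounds.

Compound 1 `COc1cc(-c2cc(/C=C/C(=O)c3ccc(N)cc3)[nH]n2)cc(OC)c1OC` and compound 2 `COc1ccc(-c2cc(/C=C/C(=O)c3ccc(N)cc3)[nH]n2)cc1OC` share a core and differ only by hydrogen in place of methoxy on an aromatic carbon. In a functional assay on Malme-3M cells (Homo sapiens) for cytotoxicity, read by sulforhodamine B assay, with a stated time of 48 h, tested at 100 uM (a higher number here means a weaker effect of the compound at the concentration tested, a lower number a stronger effect), compound 1 gives -76%, and compound 2 gives -75%; the step of a number 1 percentage points higher from compound 1 to compound 2 (within the scatter) is within the scatter. Compound 3 `COc1cc(C(=O)/C=C/c2cc(-c3cc(OC)c(OC)c(OC)c3)n[nH]2)cc(OC)c1OC` is built on a different core, and the difference between the two cores is not broken down here. In this assay compound 3 gives -94%, the lowest of the three numbers. Compound 4 `COc1ccc(-c2cc(/C=C/C(=O)c3cc(OC)c(OC)c(OC)c3)[nH]n2)cc1OC` differs from compound 3 by hydrogen in place of methoxy on an aromatic carbon, the same change as from compound 1 to compound 2. Because a number 1 percentage points higher from compound 1 to compound 2 (within the scatter) stayed within the scatter, the step of a number 4 percentage points higher from compound 3 to compound 4 (within the scatter) is expected to be small as well. Compound 4 is therefore estimated at -90%, expected between -100% and -75%.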

Compound 4, a percentage reported as activity, at one concentration (the size of the read-out at that concentration, not a potency): -62%
For compound 4 the middle estimate is 28 percentage points below the measured one; the measured number lies above the stated range.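

In this assay the new step is a number 32 percentage points higher from compound 3 to compound 4 (beyond the scatter), so putting hydrogen in place of methoxy on an aromatic carbon does not stay a small step when moved from one core to the other. The two steps from this one change clearly differ: the same change on two cores in this assay, a number 1 percentage points higher (within the scatter) from compound 1 to compound 2 and a number 32 percentage points higher (beyond the scatter) from compound 3 to compound 4, 31 percentage points apart, beyond the scatter of two such steps This shows that, for these two pairs, the effect of the change depends on the core around it, but it does not show why, and two pairs give no rule for any other core.

Left open is whether a hydroxy group or a chlorine atom in that place would follow the small step or the large one. As far as these compounds go, how the same change behaves on a third core also remains open.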